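From Trifluoromethyl to Dimethylamino on the Aromatic Ring

The compounds below may be only part of what the source reports. "The series", "measured", "known", "first", "only" and "open" are said of these compounds alone.

Of the compounds shown here, two have so far been measured in a functional assay on the whole organism (Hindlimb) for inhibition, with Mus musculus as the target, with a stated time of 4 h; on this read-out higher numbers stand for an effect only at larger amounts of compound and lower numbers for an effect already at smaller amounts. Compound 1 `CC1(C)CC12NC(=O)N(NC(=O)c1ccc(Cl)cc1)C2=O` gives 300 mg/kg, and compound 2 `CC1(C)CC12NC(=O)N(NC(=O)c1ccc(C(F)(F)F)cc1)C2=O` gives 30 mg/kg. Within the data shown here, the single step between them, a 10-fold lower number from compound 1 to compound 2 (1.00 log units; beyond the scatter), shows that the group on this aromatic carbon matters. Among the measured compounds shown here, compound 2 thus stands at the lowest of the two numbers, with compound 1 as its only neighbour.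

Compound 3 `CN(C)c1ccc(C(=O)NN2C(=O)NC3(CC3(C)C)C2=O)cc1` is the next compound; its difference from compound 2 is dimethylamino in place of trifluoromethyl on an aromatic carbon. For the measured compounds named here, no measured step involves dimethylamino, so the one known step, which concerns chloro and trifluoromethyl, bears on this change only by showing the position to be sensitive. The step expected in this assay is a 3.3-fold higher number from compound 2 to compound 3 (0.52 log units; beyond the scatter), directed towards a higher number but with wide uncertainty. Compound 3 is estimated at 100 mg/kg, within a range from 30 mg/kg to 300 mg/kg.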

Compound 3, minimum effective dose: 300 mg/kg
The estimate for compound 3 lay 3.0-fold (0.48 log units) below the measured number; low and high end bracket the measured number.
By their numbers in this assay, from the lowest: compound 2; then compounds 1 and 3 (each within the scatter of the next).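

In this assay, replacing trifluoromethyl with dimethylamino gives a 10-fold higher number from compound 2 to compound 3 (1.00 log units; beyond the scatter), so the incoming group does not keep the low number seen with trifluoromethyl. Replacing chloro with dimethylamino gives no change at the digits printed from compound 1 to compound 3 (within the scatter), so these two groups cannot be told apart in this read-out, even though they differ in their atoms. Among the three groups tested on this aromatic carbon, trifluoromethyl alone stands apart, and no measurement of any property of these groups is available to account for this.

The compounds shown leave open whether trifluoromethyl is unique here or whether a nitrile, a methoxy group or bromo on the same carbon would match compound 2 or go lower. As far as these compounds go, it also remains open how a carboxylic acid or a longer chain at this carbon would read out on the shared core.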